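The source may hold more compounds than are shown below. What is called first, only, known or untested is meant among the compounds shown, and "the series" means these compounds.

In an in vitro ADME assay on microsomes from liver (Homo sapiens) for metabolic stability (a higher number here means that the compound lasts longer, a lower number that the compound disappears faster), compound 1 (`CCc1n[nH]c(CC)c1Oc1cccc(C#N)c1`) gives 0.617 h. Compound 3 (`CCc1nn(CCO)c(CC)c1Oc1cc(Cl)cc(C#N)c1`) gives 1.12 h, and these two numbers lie within the scatter of each other. Compound 2 (`CCc1n[nH]c(CC)c1Oc1cc(C#N)cc(C#N)c1`) is reported only as a limit, > 2 h, and not as a number. For the measured compounds named here, the one measured change in a single place, cyano in place of hydrogen on an aromatic carbon, is an at least 3.2-fold higher number from compound 1 to compound 2 (0.51 log units; beyond the scatter), and this size rests on (the limit of > 2 h in this assay, at which 1 of the 3 values shown sits).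

Compound 4 (`CCc1nn(CCN)c(CC)c1Oc1cccc(C#N)c1`) is changed elsewhere on the core of compound 1: 2-aminoethyl in place of hydrogen on an aromatic nitrogen. The cyano step concerns an aromatic carbon and not an aromatic nitrogen, so it gives little guidance on size here. Going by the values given here, compound 3, with 1.12 h, is the only measured compound that bears a chain on an aromatic nitrogen. Its chain is a different one, and it also differs from compound 1 in a second place, so it offers only a loose reference, though its value stays within the scatter of compound 1. No step beyond the scatter is therefore expected. The expected change is a 1.5-fold higher number from compound 1 to compound 4 (0.16 log units; within the scatter). The estimated half-life of compound 4 is 0.9 h, with an expected range from 0.4 h to 2 h.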

Compound 4, half-life: > 2 h
Compound 4 ended at the assay's limit; the forecaster's own chance of this, stated with the estimate: 15%; middle value at least 2.2-fold (0.34 log units) from the limit.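

In this assay, the aromatic nitrogen of the core of compound 1 now has a measured step of its own: 2-aminoethyl in place of hydrogen gives an at least 3.2-fold higher number from compound 1 to compound 4 (0.51 log units; beyond the scatter). For the compounds shown here, until now, the only step beyond the scatter lay on an aromatic carbon, and compound 3, the only earlier compound with a chain on an aromatic nitrogen, also differed from compound 1 in a second place, so it could not show what this position does alone. Compound 4 gives > 2 h, which is a limit and not a number, so the new step shows a change at this nitrogen but fixes only its lower bound, and its size rests on this: the limit of > 2 h in this assay, at which 2 of the 4 values shown sit.

What the compounds shown leave open is whether this step belongs to the amine of the 2-aminoethyl group or would come with any chain on this nitrogen. A plain ethyl group, a 2-hydroxyethyl chain or a longer 3-aminopropyl chain on the core of compound 1 would separate these two readings, and a measured number in place of a limit would give the step its full size.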